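The source may report more compounds than this note shows. Statements on the series, on what has been measured and on what is new or still open speak of the compounds shown alone.

Compounds measured so far:
- Compound 1, `N#Cc1c(Nc2ccc(C(F)(F)F)cc2)sc2ccccc12`: 65%
- Compound 2, `N#Cc1c(Nc2ccc(N)cc2)sc2ccccc12`: 51%

Both were tested in a functional assay on HUVEC cells (Homo sapiens), read by fluorescence and microscopy, with a stated time of 6 h, tested at 250 nM; on this read-out higher numbers stand for a weaker effect at the one concentration tested and lower numbers for a stronger effect. Of these two numbers, compound 2 holds the lower one, the step of a number 14 percentage points lower from compound 1 to compound 2 (beyond the scatter) setting it apart from compound 1 by more than the usual scatter. Compound 3, `N#Cc1c(Nc2ccc(Cl)cc2)sc2ccccc12`, has not yet been measured. Its difference from compound 2 is chloro in place of amino on an aromatic carbon. Within the data shown here, only one measured step exists to lean on: a number 14 percentage points lower from compound 1 to compound 2 (beyond the scatter), which shows that replacing trifluoromethyl by amino at this position lowered the number modestly. Chloro, like trifluoromethyl, carries no hydrogen-bond donor or acceptor, so the reverse direction seems the more likely one, giving a number for compound 3 that is expected to climb back toward that of compound 1, by about a number 9 percentage points higher from compound 2 to compound 3 (within the scatter). The estimate for compound 3 in this assay is 60%, with a range from 45% to 75%.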

Compound 3, a percentage reported as activity, at one concentration (the size of the read-out at that concentration, not a potency): 45%
Beside the measured number, compound 3's estimate is 15 percentage points above it, and the stated range covers the measured number.
By their numbers in this assay, from the lowest: compounds 3 and 2 (each within the scatter of the next); then compound 1.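

In this assay, the step of a number 6 percentage points lower from compound 2 to compound 3 (within the scatter) means that chloro and amino at this place cannot be told apart, even though amino has 1 hydrogen-bond donor and 1 hydrogen-bond acceptor and chloro has neither. The earlier pair alone could not show this, and the step of a number 20 percentage points lower from compound 1 to compound 3 (beyond the scatter) now shows that trifluoromethyl stands apart from chloro as well as from amino, so the number moves with either replacement of trifluoromethyl. No measurement shown here explains why these groups compare this way.

Still open, going by these compounds, is how a methyl, a methoxy or a carboxylic acid at this same place would compare with these three groups. On these data alone, it is also open whether any such group would stand clearly apart from both chloro and amino.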